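Swapping an aryl for isopropyl on the amide nitrogen

The source may report more compounds than this note shows. Statements on the series, on what has been measured and on what is new or still open speak of the compounds shown alone.

Measured so far:
compound 1, `CC(=O)c1ccc(NC(=O)c2nc(-c3ccccc3)n(-c3ccc(S(N)(=O)=O)cc3)n2)cc1`: 53%
compound 2, `NNC(=O)c1nc(-c2ccccc2)n(-c2ccc(S(N)(=O)=O)cc2)n1`: 32%

Both measured compounds were tested in a functional assay on the whole organism for inhibition, with Rattus norvegicus as the target, read by paw edema, with stated times of 30 min and 1 h, at a dose of 0.28 mmol/kg by the oral route; a higher number here means more inhibition at the dose given (going by the name of the read-out), a lower number less inhibition. Among the compounds with values here, compound 1 stands highest of the two numbers; the nearest is compound 2, and the only measured step is a number 21 percentage points lower from compound 1 to compound 2 (beyond the scatter). Compound 3, `CC(C)NC(=O)c1nc(-c2ccccc2)n(-c2ccc(S(N)(=O)=O)cc2)n1`, has not yet been measured. It differs from compound 1 in one place: isopropyl in place of 4-acetylphenyl on an amide-type nitrogen.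

Within the data shown here, the single step that bears on this change is the one from compound 1 to compound 2, where the whole 4-acetylphenyl was also taken off the amide-type nitrogen and the number fell by a modest amount beyond the scatter. Isopropyl also lacks the six-membered aromatic ring. On that basis a downward step of similar size is expected, a number 18 percentage points lower from compound 1 to compound 3 (beyond the scatter). Compound 3 is therefore estimated at 35%, with a range from 20% to 50%.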

Compound 3, a percentage reported as inhibition, in the whole organism at one dose (the size of the read-out at that dose, not a potency): 21%
The estimate for compound 3 lay 14 percentage points above the measured number, within the range that was stated.
By their numbers in this assay, from the lowest: compound 3; then compound 2; then compound 1.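

The change from 4-acetylphenyl to isopropyl on the amide-type nitrogen brings a number 32 percentage points lower from compound 1 to compound 3 (beyond the scatter) in this assay, a larger fall than the one seen with amino in that place. Isopropyl also stands apart from amino, with a number 11 percentage points lower from compound 2 to compound 3 (beyond the scatter), so the loss at this position depends on the group that enters as well as on the 4-acetylphenyl that leaves. No measurement here explains why these three groups rank as they do.

On these data alone, what remains open is whether the higher number of compound 1 rests on the six-membered aromatic ring or on the acetyl attached to it, a question that a plain phenyl on the same nitrogen could help to settle. As far as these compounds go, it is also open how a benzyl group or a longer chain such as n-butyl would compare with isopropyl.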